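From thiophen-2-yl to phenyl on the shared core

A few compounds are considered here, and "the series" means these few. Any claim that something is new, unique, unknown or untested is made for them only; others in the source may bear on it.

Measured in a functional assay on ECa-109 cells (Homo sapiens) for antiproliferative activity, read by MTT assay, with a stated time of 72 h; on this read-out higher numbers stand for weaker inhibition and lower numbers for stronger inhibition:
- Compound 1 `CCCSc1nc(N/N=C/c2cccnc2)c2nnn(Cc3ccccc3)c2n1` gives > 64000 nM (a limit, not a number)
- Compound 2 `CCCSc1nc(N/N=C/c2ccccc2Cl)c2nnn(Cc3ccccc3)c2n1` gives 6180 nM (a number)
- Compound 3 `CCCSc1nc(N/N=C/c2cccs2)c2nnn(Cc3ccccc3)c2n1` gives > 64000 nM (a limit, not a number)

Compound 3 sits at the limit of > 64000 nM in this assay, at which 2 of the 3 values shown sit, and so has no exact number. Compound 4 `CCCSc1nc(N/N=C/c2ccccc2)c2nnn(Cc3ccccc3)c2n1` differs from it as follows: phenyl in place of thiophen-2-yl on a carbon with a double bond to nitrogen. This puts phenyl in place of thiophen-2-yl on a carbon with a double bond to nitrogen. Going by the values given here, two measured steps bear on this, an at least 10-fold higher number from compound 2 to compound 3 (1.01 log units; beyond the scatter) and an at least 10-fold lower number from compound 1 to compound 2 (1.01 log units; beyond the scatter), both large. Each involves 2-chlorophenyl, the only other six-membered ring of carbon only here, carried by compound 2 at 6180 nM in this assay. A lower number is therefore expected, though perhaps a smaller move, and the limit may persist. The expected change is an at least 2.9-fold lower number from compound 3 to compound 4 (0.46 log units; beyond the scatter) in this assay, if a number is reported at all. Compound 4 is estimated at 22000 nM, within an expected range of 7000 nM to 64000 nM in this assay.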

Compound 4, half-maximal inhibitory concentration: > 64000 nM
Compound 4: no number, only a limit; the forecaster's own chance of this, stated with the estimate: 40%; at least 2.9-fold (0.46 log units) between middle value and limit.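

The chloro group turns out to carry the effect on this ring: in this assay, hydrogen in its place gives an at least 10-fold higher number from compound 2 to compound 4 (1.01 log units; beyond the scatter). A plain phenyl ring is therefore not enough, and of the compounds shown, only compound 2 gives a number. The steps to compound 4 from compound 1 and compound 3 cannot be read, as all three compounds sit at one limit and have no exact number: the limit of > 64000 nM in this assay, at which 3 of the 4 values shown sit.

The compounds shown leave open whether another group on the phenyl ring, such as fluoro, methoxy or an amine, would also give a number. As far as these compounds go, the order among phenyl, thiophen-2-yl and pyridin-3-yl also remains unknown.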